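This account rests on a few compounds, and the source may have more. Where it says the series, first, only, none or still open, it means among the compounds named here.

In a functional assay on HeLa cells (Homo sapiens) for antiproliferative activity, read by sulforhodamine B assay, with a stated time of 72 h (a lower number here means a stronger inhibitor, a higher number a weaker inhibitor), compound 2 `COc1ccc2nc(Cl)c(/C=C\c3ccc(C(F)(F)F)cc3C(F)(F)F)cc2c1` gives > 50000 nM as a limit of the assay, not a number. Compound 3 `COc1ccc2nc(Cl)c(/C=C\c3ccccc3C(F)(F)F)cc2c1` differs from it by hydrogen in place of trifluoromethyl on an aromatic carbon on an aromatic carbon, meta to a trifluoromethyl group and para to a large group. Compound 1 `COc1ccc2nc(Cl)c(/C=C\c3ccc(C(F)(F)F)cc3)cc2c1` gives 16200 nM in this assay and is the only measured reference. Among the measured compounds shown here, one measured step bears on the change, an at least 3.0-fold higher number from compound 1 to compound 2 (0.48 log units; beyond the scatter) for trifluoromethyl in place of hydrogen, though a different trifluoromethyl leaves here. A reversal of modest size is therefore expected, toward a lower number, with an at least 2.2-fold lower number from compound 2 to compound 3 (0.35 log units; beyond the scatter) as the estimated step. For compound 3 the estimate is 22000 nM (range 7000 nM to 50000 nM) and a limit reading remains possible.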

Compound 3, half-maximal inhibitory concentration: 2600 nM
Beside the measured number, compound 3's estimate is 8.5-fold (0.93 log units) above it; measured number below the stated range.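

In this assay, hydrogen in place of trifluoromethyl at this position, para to a large group, gives an at least 19-fold lower number from compound 2 to compound 3 (1.28 log units; beyond the scatter). The series thus gains its first step toward a lower number, and a trifluoromethyl on this carbon is shown not to be required for a measurable value. Compound 2 stands at a limit of the assay, not at a number, so the step gives only a bound: the limit of > 50000 nM in this assay, at which 1 of the 3 values shown sits.

From the compounds shown here alone, it remains open whether a fluorine, a methoxy group or an amine on this carbon would read like hydrogen or like trifluoromethyl. Going by these compounds, the part played by the remaining trifluoromethyl of compound 3 is also open.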